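Chain extension at the aromatic nitrogen of the shared core

The source may report more compounds than this note shows. Statements on the series, on what has been measured and on what is new or still open speak of the compounds shown alone.

Measured so far in a functional assay on a cell-free system (plasma) for inhibition of platelet-activating factor acetylhydrolase (Homo sapiens), tested at 100 nM; a higher number here means more inhibition at the concentration tested (going by the name of the read-out), a lower number less inhibition:
compound 1, `CCCCCCCCN(C)C(=O)Cn1cc(Cc2cnc(=O)n(CC)c2)c(=O)nc1SCc1ccc(F)cc1`, 48%;
compound 2, `CCCCCCCCN(C)C(=O)Cn1cc(Cc2cnc(=O)n(CCO)c2)c(=O)nc1SCc1ccc(F)cc1`, 59%.

Compound 2 stands highest of the two numbers; its nearest neighbour is compound 1, the step being a number 11 percentage points higher from compound 1 to compound 2 (beyond the scatter). Compound 3, `CCCCCCCCN(C)C(=O)Cn1cc(Cc2cnc(=O)n(CC(=O)NCCC)c2)c(=O)nc1SCc1ccc(F)cc1`, differs from compound 2 by propylcarbamoyl in place of hydroxymethyl on a saturated chain carbon bound to an aromatic nitrogen. Going by the values given here, the only measured step, a number 11 percentage points higher from compound 1 to compound 2 (beyond the scatter), concerns the same chain but a different change, so it bears on the present step only loosely. No comparable replacement has been measured, so for compound 3 a step of a number 4 percentage points lower from compound 2 to compound 3 (within the scatter) in this assay is expected, that is, nothing beyond the scatter. Compound 3 is estimated at 55%, range 35% to 75%.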

Compound 3, a percentage reported as inhibition, at one concentration (the size of the read-out at that concentration, not a potency): 42%
Estimate against measurement, compound 3: 13 percentage points above, within the range that was stated.
By their numbers in this assay, from the lowest: compounds 3 and 1 (each within the scatter of the next); then compound 2.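

In this assay, propylcarbamoyl in place of hydroxymethyl on the saturated chain carbon bound to the aromatic nitrogen gives a number 17 percentage points lower from compound 2 to compound 3 (beyond the scatter), so the gain seen with the hydroxy group does not carry over to this larger group. Propylcarbamoyl in place of methyl at the same carbon gives a number 6 percentage points lower from compound 1 to compound 3 (within the scatter), which leaves these two groups indistinguishable here. Nothing available explains either step.

Open, going by these compounds, is whether a longer hydroxyalkyl chain would improve on compound 2. Also open, on these data alone, is how a carboxylic acid or an amine at the end of this chain would compare.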